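A few compounds are considered here, and "the series" means these few. Any claim that something is new, unique, unknown or untested is made for them only; others in the source may bear on it.

Measured compounds:
- compound 1, `CC1CCN(c2c(S(=O)(=O)c3cccc(Cl)c3)cnc3cc(Cl)ccc23)CC1`, 92%
- compound 2, `Cc1ccc(S(=O)(=O)c2cnc3ccc(Cl)cc3c2N2CCC(C)CC2)cc1F`, 68%
- compound 3, `COCC1CCN(c2c(S(=O)(=O)c3cc(F)cc(F)c3)cnc3cc(F)ccc23)CC1`, 83%

In an assay on isolated protein for displacement of a labelled ligand from metabotropic glutamate receptor 5 (Homo sapiens), with a stated time of 60 min, tested at 1 uM (a higher number here means more inhibition at the concentration tested (going by the name of the read-out), a lower number less inhibition), compound 1 gives the highest of the three numbers. Compound 3 comes nearest, and its number lies within the usual scatter of compound 1, so no order between those two can be claimed. Compound 2 stands furthest away, beyond the scatter, so compound 1 does give more inhibition than compound 2 on these numbers.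

The unmeasured compound 4 `Cc1ccc(S(=O)(=O)c2cnc3cc(Cl)ccc3c2N2CCC(C)CC2)cc1` differs from compound 1 in one place: 4-methylphenyl in place of 3-chlorophenyl on a sulfonyl sulfur. Among the measured compounds shown here, no measured pair shows this exact change on the shared core, so its size must be judged from what the three numbers show. Compound 2, which also carries a methyl on the aryl ring of the sulfone though with a further fluorine and a differently substituted core, sits below compound 1, which hints that the change may cost some inhibition. Compound 4 is therefore expected to give a step of a number 12 percentage points lower from compound 1 to compound 4 (beyond the scatter) in this assay, a modest fall, possibly within the scatter. The estimate for compound 4 is 80%, with a range from 62% to 94%.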

Compound 4, a percentage reported as inhibition, at one concentration (the size of the read-out at that concentration, not a potency): 94%
Beside the measured number, compound 4's estimate is 14 percentage points below it, within the range that was stated.
By their numbers in this assay, from the lowest: compound 2; then compounds 3, 1 and 4 (each within the scatter of the next, the first and the last beyond it).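

In this assay, among the compounds shown here, this is the first pair to isolate the group on a sulfonyl sulfur, and it gives a number 2 percentage points higher from compound 1 to compound 4 (within the scatter), so 4-methylphenyl in place of 3-chlorophenyl leaves the number unchanged within the scatter on the shared core. A methyl-bearing aryl ring at this place is therefore compatible with a high read-out, and on this core the chlorine is not needed to keep it. No available evidence bears on why the two groups read alike.

The compounds shown leave open what happens when the phenyl ring at this place gives way to a pyridine ring, or when it carries an amine or a carboxylic acid. They also leave open whether compound 1 and compound 4 would still read alike at a lower concentration, since a single-concentration number is not a potency.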